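Methylsulfonyl in place of chloro: compound 1 to compound 4

The source may hold more compounds than are shown below. What is called first, only, known or untested is meant among the compounds shown, and "the series" means these compounds.

Compound 1 `Cc1cnc(Nc2ccc(Cl)cc2)nc1Nc1nc2ccccc2s1` is the reference for this step. As far as these compounds go, in a functional assay on MCF7 cells (Homo sapiens) for antiproliferative activity, read by MTT assay, with a stated time of 48 h (on this read-out higher numbers stand for weaker inhibition and lower numbers for stronger inhibition), compound 1 gives only a limit, > 50000 nM, not a number, so where it truly stands among the measured analogues is unknown; it sits at the limit of > 50000 nM in this assay, at which 1 of the 3 values shown sits.

Compound 4 `Cc1cnc(Nc2ccc(S(C)(=O)=O)cc2)nc1Nc1nc2ccccc2s1` differs from compound 1 by methylsulfonyl in place of chloro on an aromatic carbon.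

Within the data shown here, no measured step in this assay involves a chloro or a methylsulfonyl, so none bears directly on this change. Among the measured compounds shown here, the one measured step, a 2.7-fold lower number from compound 2 to compound 3 (0.43 log units; beyond the scatter), concerns a methyl added on an aromatic carbon of a different core and is set aside. Compound 2 `NS(=O)(=O)c1ccc(Nc2nccc(Nc3nc4ccccc4s3)n2)cc1` gives 15300 nM in this assay, and compound 3 `Cc1ccc2nc(Nc3ccnc(Nc4ccc(S(N)(=O)=O)cc4)n3)sc2c1` gives 5740 nM; both carry a sulfonamide and reach measurable numbers, though their core differs from that of compound 1.

Compound 4 is therefore estimated at 30000 nM, within 8000 nM to 100000 nM, with a fair chance that only a limit is again reported. The step of an at least 1.6-fold lower number from compound 1 to compound 4 (0.22 log units; that floor lies within the scatter) is expected to be weak.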

Compound 4, half-maximal inhibitory concentration: 6550 nM
Estimate against measurement, compound 4: 4.6-fold (0.66 log units) above; measured number outside the range, below it.
By their numbers in this assay, from the lowest: compounds 3 and 4 (each within the scatter of the next); then compound 2. At a limit, above all of these: compound 1.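

Methylsulfonyl in place of chloro gives an at least 7.6-fold lower number from compound 1 to compound 4 (0.88 log units; beyond the scatter) in this assay, so on this core the position on the six-membered aromatic ring of carbon only responds to this change. Compound 4 is the only compound shown on this core with a measured number, and the earlier compounds said nothing about this position. The step gives only a floor and not a true size because compound 1 has only a limit: the limit of > 50000 nM in this assay, at which 1 of the 4 values shown sits.

The compounds shown leave open whether the gain is specific to methylsulfonyl, as an amine, a carboxylic acid or a sulfonamide at this position could give a higher or lower number than compound 4. Also open, as far as these compounds go, is how a longer chain on the sulfonyl would read in this assay.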